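The source may report more compounds than this note shows. Statements on the series, on what has been measured and on what is new or still open speak of the compounds shown alone.

In a functional assay on CHO cells for antagonist activity at prostaglandin E2 receptor EP1 subtype (Homo sapiens), read by FLIPR and calcium flux (on this read-out higher numbers stand for weaker inhibition and lower numbers for stronger inhibition), two compounds have been measured so far. Compound 1, with the structure `Cc1ccc(S(=O)(=O)N(Cc2nnc(Cc3ccccc3F)o2)c2cccc(Cl)c2C)cc1`, gives 631 nM in this assay, which is the higher of the two numbers and therefore the weaker of the two. Compound 2, with the structure `CCOc1ccc(Cc2nnc(CN(c3cccc(Cl)c3Cl)S(=O)(=O)c3ccc(C(F)(F)F)cc3)o2)cc1`, gives 6.31 nM in this assay, a far lower number that lies well beyond the scatter of the method. Compound 2 differs from compound 1 in several places at once, so no single structural step can be read from that pair, and nothing else in the pair is known.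

Compound 3, with the structure `COc1ccc(NCc2nnc(CN(c3cccc(Cl)c3C)S(=O)(=O)c3ccc(C)cc3)o2)cc1`, has not yet been measured. It differs from compound 1 in one place: (4-methoxyphenyl)amino in place of 2-fluorophenyl on a saturated chain carbon bound to an aromatic carbon. With no measured step of this kind in hand, any expectation rests on compound 1 alone, and the step from compound 1 to compound 3 in this assay is expected to be modest, towards a lower number, as a 2.5-fold lower number from compound 1 to compound 3 (0.40 log units; beyond the scatter). For compound 3 in this assay the estimate is 250 nM, with a range from 60 nM to 1000 nM.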

Compound 3, inhibition constant: 79.4 nM
For compound 3 the middle estimate is 3.1-fold (0.50 log units) above the measured one; low and high end bracket the measured number.
By their numbers in this assay, from the lowest: compound 2; then compound 3; then compound 1.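

Placing (4-methoxyphenyl)amino in place of 2-fluorophenyl on a saturated chain carbon bound to an aromatic carbon gives a 7.9-fold lower number from compound 1 to compound 3 (0.90 log units; beyond the scatter) in this assay, and this is the first single change in the set that can be read on its own. It shows that this position responds to substitution and that 2-fluorophenyl is not needed there for inhibition, since the group that enters, with more heavy atoms and a hydrogen-bond donor, gives stronger inhibition on the same core. Nothing measured here shows what lies behind this step.

The change alters several things at once, swapping the ring substituents and adding an amino link, so the share of the methoxy group, the nitrogen and the loss of fluorine cannot be separated. Phenylamino, which keeps the nitrogen without the methoxy group, or 4-methoxybenzyl, which keeps the methoxy group without the nitrogen, would be needed to pull these apart, and the outcome for either cannot be told from the compounds shown.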